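Heteroaryl amide exchange: from compound 3 to compound 4

The source may hold more compounds than are shown below. What is called first, only, known or untested is meant among the compounds shown, and "the series" means these compounds.

Compound 3 `COc1cc(C(N)=O)cc2nc(NC(=O)c3cccnn3)n(CCCNC(=O)OCc3ccccc3)c12` carries pyridazin-3-yl on the amide carbonyl carbon. In an assay for activation of interferon regulatory factor 3 (Homo sapiens), read by a luciferase reporter, with a stated time of 20 h (on this read-out higher numbers stand for an effect only at larger amounts of compound and lower numbers for an effect already at smaller amounts), compound 3 gives only a limit, > 100000 nM. Compound 1 `COc1cc(C(N)=O)cc2nc(NC(=O)c3ccc4ccccc4n3)n(CCCNC(=O)OCc3ccccc3)c12`, with quinolin-2-yl at that position, also gives only a limit in this assay, > 100000 nM. Compound 2 `COc1cc(C(N)=O)cc2nc(NC(=O)c3ccccn3)n(CCCNC(=O)OCc3ccccc3)c12`, with pyridin-2-yl, likewise reaches only a limit in this assay, > 100000 nM. All three measured values therefore sit at the limit of > 100000 nM in this assay, at which 3 of the 3 values shown sit, and the steps a step that the two limits leave unreadable from compound 1 to compound 2, a step that the two limits leave unreadable from compound 1 to compound 3 and a step that the two limits leave unreadable from compound 2 to compound 3 cannot be read in size or direction; compound 3 stands nowhere distinguishable from the other two.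

Compound 4 `CCn1nccc1C(=O)Nc1nc2cc(C(N)=O)cc(OC)c2n1CCCNC(=O)OCc1ccccc1` differs from compound 3 by 1-ethyl-1H-pyrazol-5-yl in place of pyridazin-3-yl on a carbonyl carbon. Within the data shown here, no measured step gives a size for such a change; every heteroaryl exchange made so far has left the read-out at the limit of > 100000 nM in this assay, at which 3 of the 3 values shown sit. The expectation is that compound 4 again stays at the limit in this assay, with no step beyond the scatter, a step that the limit leaves unreadable from compound 3 to compound 4. Compound 4 is estimated at 150000 nM, with a range from 30000 nM to 1000000 nM, and most probably the assay will again report a limit rather than a number.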

Compound 4, half-maximal effective concentration: > 100000 nM
Compound 4: no number, only a limit (the forecaster's own chance of this, stated with the estimate: 85%); the middle value does not contradict the limit.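

In this assay compound 4 gives > 100000 nM, which is a limit and not a number, so the steps to compound 4 from compound 1, compound 2 and compound 3 cannot be read: the limit of > 100000 nM in this assay, at which 4 of the 4 values shown sit.

The compounds shown leave open whether any group on this carbonyl carbon gives a numerical half-maximal effective concentration in this assay, and how the four compounds rank.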